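Swapping pyridin-2-yl for quinolin-6-yl on the amide carbonyl

This account rests on a few compounds, and the source may have more. Where it says the series, first, only, none or still open, it means among the compounds named here.

Measured in a functional assay on HCT-15 cells (Homo sapiens) for antiproliferative activity (a higher number here means a weaker inhibitor, a lower number a stronger inhibitor), with one compound still to be tested:

- compound 1 `COc1ccc(S(=O)(=O)Oc2ccccc2NC(=O)c2ccncc2)cc1`: 89 nM
- compound 2 `COc1ccc(S(=O)(=O)Oc2ccccc2NC(=O)Nc2ccccc2)cc1`: > 10000 nM, a limit of the assay and not a number
- compound 3 `COc1ccc(S(=O)(=O)Oc2ccccc2NC(=O)c2ccccn2)cc1`: 110 nM

Compound 3 stands level with compound 1, and the step of a 1.2-fold higher number from compound 1 to compound 3 (0.09 log units; within the scatter) shows the two cannot be told apart. Compound 2 lies far from both, at the limit of > 10000 nM in this assay, at which 1 of the 3 values shown sits.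

The next compound, compound 4 `COc1ccc(S(=O)(=O)Oc2ccccc2NC(=O)c2ccc3ncccc3c2)cc1`, carries quinolin-6-yl in place of pyridin-2-yl on a carbonyl carbon. For the measured compounds named here, two measured steps bear on this change. Exchanging pyridin-4-yl for pyridin-2-yl made no difference beyond the scatter, as the step of a 1.2-fold higher number from compound 1 to compound 3 (0.09 log units; within the scatter) shows. Replacing anilino was a different matter, with large steps of an at least 110-fold higher number from compound 1 to compound 2 (2.05 log units; beyond the scatter) and an at least 90-fold lower number from compound 2 to compound 3 (1.95 log units; beyond the scatter), although both rest on a limit. The group on the carbonyl carbon can therefore matter greatly in this assay, yet neither step tests a group as large as quinolin-6-yl. Since compound 4 keeps an amide-type nitrogen on that carbonyl carbon, no step beyond the scatter is expected, though the range must stay wide. The expected step is a 1.4-fold higher number from compound 3 to compound 4 (0.13 log units; within the scatter). For compound 4 the estimated value is 150 nM, with an expected range of 40 nM to 800 nM.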

Compound 4, half-maximal inhibitory concentration: > 10000 nM
Compound 4 was reported as a limit (the forecaster's own chance of this, stated with the estimate: 5%); middle value at least 66-fold (1.82 log units) from the limit.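

Keeping the amide-type nitrogen on the carbonyl carbon does not by itself preserve activity in this assay: quinolin-6-yl gives an at least 90-fold higher number from compound 3 to compound 4 (1.95 log units; beyond the scatter), and set against pyridin-4-yl it gives an at least 110-fold higher number from compound 1 to compound 4 (2.05 log units; beyond the scatter), with both steps resting on a limit. The earlier exchange of pyridin-4-yl for pyridin-2-yl stayed within the scatter, so a single six-membered aromatic ring with its one hetero atom was accepted in either form, whereas quinolin-6-yl, with its added six-membered aromatic ring of carbon only, is not. Compound 2 and compound 4 both stand at a limit of the assay and not at a number, so the step between them cannot be read: the limit of > 10000 nM in this assay, at which 2 of the 4 values shown sit.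

The compounds shown do not separate the effect of the added ring from that of where quinolin-6-yl is attached to the carbonyl carbon. They also leave open how this position responds to a plain phenyl ring, a saturated piperidine ring or a small methyl group.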